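This account rests on a few compounds, and the source may have more. Where it says the series, first, only, none or still open, it means among the compounds named here.

Compound 1, `COc1cc(CNc2nc3cc(N)cc(N)c3nc2-c2ccccc2)cc(OC)c1OC`, in a functional assay on OVCAR-8 cells (Homo sapiens) for inhibition, read by sulforhodamine B assay, with a stated time of 48 h (on this read-out higher numbers stand for lower toxicity in this test and lower numbers for higher toxicity in this test), gives 31600 nM. Compound 2, `CCOC(=O)[C@H](CCC(=O)O)NC(=O)c1ccc(Oc2nc3cc(N)cc(N)c3nc2-c2ccccc2)cc1`, in this assay gives < 100000 nM, which is a limit of the assay and not a number. Compound 3, `COc1ccc(Sc2nc3cc(N)cc(N)c3nc2-c2ccccc2)cc1`, in this assay gives < 100000 nM, again a limit of the assay rather than a number.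

Compound 3 therefore stands at the edge of what this test reports: its value is only a limit, and the limit of < 100000 nM in this assay, at which 2 of the 3 values shown sit, shows that it shares this position with one other compound, while compound 1 alone yields a number.

Compound 4, `Nc1cc(N)c2nc(-c3ccccc3)c(Sc3ccc(F)cc3)nc2c1`, is not yet measured in this assay. It differs from compound 3 in one place: fluoro in place of methoxy on an aromatic carbon, the same difference read one bond further out as (4-methoxyphenyl)sulfanyl to (4-fluorophenyl)sulfanyl. For the measured compounds named here, no measured pair shows the effect of this exchange here, so nothing beyond the usual scatter is expected from compound 3 to compound 4, and the result may well come back as a limit once more. Compound 4 is accordingly estimated at 60000 nM, within 15000 nM to 100000 nM, which would mean a step that the limit leaves unreadable from compound 3 to compound 4.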

Compound 4, concentration lethal to 50% of the cells: 72400 nM
The estimate for compound 4 lay 1.2-fold (0.08 log units) below the measured number, within the range that was stated.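

No step can be read between compound 3 and compound 4 in this assay, because the value of compound 3 is only a limit of the assay and not a number: the limit of < 100000 nM in this assay, at which 2 of the 4 values shown sit.

The compounds shown leave open what fluoro in place of methoxy on an aromatic carbon does to this read-out, since no pair with two numbers shows that exchange.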